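Trimming one methoxy: an estimate for growth inhibition

The source may report more compounds than this note shows. Statements on the series, on what has been measured and on what is new or still open speak of the compounds shown alone.

Measured compounds:
compound 1 `COc1ccc(CNc2nc3cc(N)cc(N)c3nc2-c2ccccc2)cc1OC` — 19100 nM
compound 2 `COc1cc(CNc2nc3cc(N)cc(N)c3nc2-c2ccccc2)cc(OC)c1OC` — 7410 nM

Among the measured compounds shown here, in a functional assay on RXF 393 cells (Homo sapiens) for inhibition, read by sulforhodamine B assay, with a stated time of 48 h (a higher number here means a weaker inhibitor of growth, a lower number a stronger inhibitor of growth), compound 1 gives 19100 nM, the higher of the two numbers known, with compound 2 reached by a 2.6-fold lower number from compound 1 to compound 2 (0.41 log units; beyond the scatter). Compound 3 `COc1ccc(CNc2nc3cc(N)cc(N)c3nc2-c2ccccc2)cc1` differs from compound 1 by hydrogen in place of methoxy on an aromatic carbon. For the measured compounds named here, the only measured step bearing on it, the gain of a methoxy from compound 1 to compound 2, was modest and ran the other way, so the loss of a methoxy is expected to raise the number modestly, perhaps not beyond the scatter. Compound 3 is therefore estimated at 30000 nM, between 12000 nM and 75000 nM, meaning an expected step of a 1.6-fold higher number from compound 1 to compound 3 (0.20 log units; within the scatter).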

Compound 3, concentration for 50% growth inhibition: 5370 nM
Estimate against measurement, compound 3: 5.6-fold (0.75 log units) above; measured number outside the range, below it.
By their numbers in this assay, from the lowest: compounds 3 and 2 (each within the scatter of the next); then compound 1.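

Removing the methoxy that sits ortho to a methoxy group lowers the number in this assay, with a 3.6-fold lower number from compound 1 to compound 3 (0.55 log units; beyond the scatter). Gaining a methoxy also lowers it, with a 2.6-fold lower number from compound 1 to compound 2 (0.41 log units; beyond the scatter), so across these compounds the number does not move in one direction with the addition or loss of methoxy groups, and compound 1 is the outlier. No evidence at hand accounts for this change. Still open, on these data alone, is how a hydroxyl, an amine or a longer ether chain at this position would compare with the hydrogen of compound 3.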